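A few compounds are considered here, and "the series" means these few. Any claim that something is new, unique, unknown or untested is made for them only; others in the source may bear on it.

Measured so far in a functional assay on DU-145 cells (Homo sapiens) for inhibition, read by trypan blue exclusion, with a stated time of 72 h; on this read-out higher numbers stand for weaker inhibition and lower numbers for stronger inhibition:
- compound 1 `Cn1c(=O)c(S(=O)(=O)c2ccc(F)cc2F)cc2cnc(Nc3ccc4cc[nH]c4c3)nc21`: 5000 nM
- compound 2 `Cn1c(=O)c(S(=O)(=O)c2ccc(F)cc2)cc2cnc(Nc3cccc4[nH]ccc34)nc21`: 750 nM
- compound 3 `Cn1c(=O)c(S(=O)(=O)c2ccc([N+](=O)[O-])cc2F)cc2cnc(Nc3ccc4[nH]ccc4c3)nc21`: 400 nM

Compound 3 gives the lowest number of the three. Its value and that of compound 2 lie within the usual scatter of each other, so no order can be read between those two; compound 1 sits well beyond the scatter, with a number far higher than that of compound 3. Among the compounds with values here, no two measured compounds differ in just one place, so no single step has been isolated in this set, and the sulfonyl-bound ring has not been varied on its own against a fixed remainder.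

Compound 4 `Cc1ccc(S(=O)(=O)c2cc3cnc(Nc4ccc5[nH]ccc5c4)nc3n(C)c2=O)cc1` has not been measured. It differs from compound 3 as follows: 4-methylphenyl in place of 2-fluoro-4-nitrophenyl on a sulfonyl sulfur. Nothing measured shows what exchanging 2-fluoro-4-nitrophenyl for 4-methylphenyl on the sulfonyl sulfur does to the number in this assay. Within the data shown here, with no step to lean on, the step expected for a 2.3-fold higher number from compound 3 to compound 4 (0.35 log units; beyond the scatter) is a modest rise in the number, possibly none beyond the scatter. Compound 4 is estimated at 900 nM, with a range from 300 nM to 3000 nM.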

Compound 4, half-maximal inhibitory concentration: 750 nM
Beside the measured number, compound 4's estimate is 1.2-fold (0.08 log units) above it; low and high end bracket the measured number.
By their numbers in this assay, from the lowest: compounds 3, 2 and 4 (each within the scatter of the next); then compound 1.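

Within the data shown here, this is the first one-place comparison: on a sulfonyl sulfur whose other neighbour is an aromatic carbon, 4-methylphenyl in place of 2-fluoro-4-nitrophenyl gives a 1.9-fold higher number from compound 3 to compound 4 (0.27 log units; within the scatter) in this assay. The exchange takes away the nitrogen, the oxygens and the fluorine of the leaving group and puts an all-carbon group in their place, yet the two values stay within the scatter, so in this pair the number does not depend on keeping 2-fluoro-4-nitrophenyl. No measurement on hand accounts for this result.

From the compounds shown here alone, the nitro group and the fluorine leave together, so their separate contributions stay open. Also open, going by these compounds, is what an amine or a carboxylic acid on this ring, or a longer chain in its place on the sulfonyl sulfur, would do to the number.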